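The source may report more compounds than this note shows. Statements on the series, on what has been measured and on what is new or still open speak of the compounds shown alone.

Measured in a functional assay on IMR-32 cells (Homo sapiens) for antiproliferative activity, read by MTT assay; on this read-out lower numbers stand for stronger inhibition and higher numbers for weaker inhibition:
- compound 1 `CC1(C)CCc2cc(C(=O)/C=C/c3ccc(OCc4cn(-c5ccc(Br)cc5)nn4)cc3)c(O)cc2O1`: 69400 nM
- compound 2 `COc1ccc(-n2cc(COc3ccc(/C=C/C(=O)c4ccc5c(c4O)CCC(C)(C)O5)cc3)nn2)c([N+](=O)[O-])c1`: 132000 nM
- compound 3 `CCc1ccccc1-n1cc(COc2ccc(/C=C/C(=O)c3ccc4c(c3O)CCC(C)(C)O4)cc2)nn1`: "not active" (no number reported)

The numbers for compound 1 and compound 2 lie within the usual scatter of each other, so neither can be ranked above the other. Compound 3 gave no number at all. Compound 4 `CCCCCn1cc(COc2ccc(/C=C/C(=O)c3cc4c(cc3O)OC(C)(C)CC4)cc2)nn1` keeps the core of compound 1 but carries pentyl in place of 4-bromophenyl on an aromatic nitrogen. For the measured compounds named here, no measured pair shows this change on its own, so the size of the step cannot be read from the data. In this assay, no shift beyond the scatter and no firm direction is expected, and the estimated step is a 1.2-fold higher number from compound 1 to compound 4 (0.06 log units; within the scatter). For compound 4 the estimated value is 80000 nM, within an expected range of 25000 nM to 250000 nM.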

Compound 4, half-maximal inhibitory concentration: "not active" (no number reported)
Compound 4 has no reported number here, so the estimate cannot be set against anything.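

For the compounds shown here, compound 4 is reported as "not active" without a number, so no step from compound 1 to compound 4 can be read. On these data alone, how far pentyl in place of 4-bromophenyl shifts the number stays open. No other data bear on this result.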